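The source may report more compounds than this note shows. Statements on the series, on what has been measured and on what is new or still open speak of the compounds shown alone.

Measured so far in a functional assay on HepG2 cells (Homo sapiens) for antiproliferative activity, read by MTT assay, with a stated time of 48 h; a higher number here means a weaker inhibitor, a lower number a stronger inhibitor:
- compound 1 `COc1ccc(CN2C(=O)C(=O)c3cc(-c4ccc(C(C)(C)C)cc4)ccc32)cc1`: 4580 nM
- compound 2 `COc1ccc(CN2C(=O)C(=O)c3cc(-c4ccc(OC(C)C)cc4)ccc32)cc1`: > 10000 nM (a limit)
- compound 3 `COc1ccc(CN2C(=O)C(=O)c3cc(-c4ccc(O)cc4)ccc32)cc1`: > 10000 nM (a limit)

Compound 3 has no number, only the limit > 10000 nM. Most of the series rests on (the limit of > 10000 nM in this assay, at which 2 of the 3 values shown sit), and compound 1 alone gives a number.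

Compound 4 `COc1ccc(CN2C(=O)C(=O)c3cc(-c4ccncc4)ccc32)cc1` carries pyridin-4-yl in place of 4-hydroxyphenyl on an aromatic carbon, meta to a fused ring and para to a fused ring: pyridin-4-yl in place of 4-hydroxyphenyl on an aromatic carbon.

Among the measured compounds shown here, no measured step makes this exact change. The nearest evidence comes from changes on the same outer ring. With hydroxy in place of tert-butyl, the result is an at least 2.1-fold higher number from compound 1 to compound 3 (0.33 log units; beyond the scatter). With isopropoxy in place of tert-butyl, the result is an at least 2.1-fold higher number from compound 1 to compound 2 (0.33 log units; beyond the scatter). Both are beyond the scatter, but each is only a bound on the true size. The remaining comparison gives a step that the two limits leave unreadable from compound 2 to compound 3, so it adds nothing on size.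

Compound 4 also lacks the tert-butyl group, so a return towards compound 1 is not expected, because an at least 2.1-fold higher number from compound 1 to compound 3 (0.33 log units; beyond the scatter) shows the loss on leaving that group. The step expected in this assay is a step that the limit leaves unreadable from compound 3 to compound 4, with no firm direction and probably none beyond the scatter. For compound 4 the estimated value is 12000 nM, with an expected range from 5000 nM to 30000 nM.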

Compound 4, half-maximal inhibitory concentration: > 10000 nM
Compound 4: only a limit was reported; the forecaster's own chance of this, stated with the estimate: 70%; the middle value does not contradict the limit.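

In this assay compound 4 gives > 10000 nM, which is a limit and not a number, so pyridin-4-yl, on this aromatic carbon meta to a fused ring and para to a fused ring, shows no measurable activity in this assay. Pyridin-4-yl in place of 4-(tert-butyl)phenyl gives an at least 2.1-fold higher number from compound 1 to compound 4 (0.33 log units; beyond the scatter), so the loss seen earlier when only the group on the outer ring changed also appears when a six-membered aromatic ring with 1 hetero atom replaces the ring of carbon only. The steps among compound 2, compound 3 and compound 4 cannot be read, so the swap of 4-hydroxyphenyl for pyridin-4-yl has no size, and compound 1 remains the only compound with a number: the limit of > 10000 nM in this assay, at which 3 of the 4 values shown sit.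

Going by these compounds, how far compound 2, compound 3 and compound 4 lie past that limit stays open, and so does whether the tert-butyl group itself, rather than any carbon-only group on that ring, accounts for the number of compound 1. A cyclohexyl or a trifluoromethyl group in its place on the outer ring would bear on that question.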